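The source may hold more compounds than are shown below. What is called first, only, known or untested is meant among the compounds shown, and "the series" means these compounds.

Measured so far:
compound 1, `CC1=CC[C@@H]([C@@](C)(O)CCCC(C)(C)NC=S)CC1`, in a functional assay on MCF7 cells (Homo sapiens) for cytotoxicity, read by sulforhodamine B assay; a lower number here means a stronger inhibitor of growth, a higher number a weaker inhibitor of growth: 63100 nM
compound 2, `CC1=CC[C@@H]([C@@](C)(O)CCCC(C)(C)NC(=S)N/N=C\c2ccc(C)cc2)CC1`, in this assay: > 100000 nM, which is a limit of the assay and not a number

Compound 2 thus stands at the edge of what this assay reports, with the limit of > 100000 nM in this assay, at which 1 of the 2 values shown sits. Compound 3, `CC1=CC[C@@H]([C@@](C)(O)CCCC(C)(C)NC(=S)N/N=C\c2ccc(O)cc2)CC1`, differs from it by hydroxy in place of methyl on an aromatic carbon. Going by the values given here, no step between measured compounds is known here, so for this change a step in this assay of small size, in either direction or none beyond the scatter, is expected. Compound 3 is estimated to give about 100000 nM, between 30000 nM and 300000 nM. That estimate corresponds to an expected a number no higher from compound 2 to compound 3 (the limit leaves the size open).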

Compound 3, concentration for total growth inhibition: 21200 nM
The estimate for compound 3 lay 4.7-fold (0.67 log units) above the measured number; the whole stated range lies above it.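

In this assay the change from 4-methylphenyl to 4-hydroxyphenyl gives an at least 4.7-fold lower number from compound 2 to compound 3 (0.67 log units; beyond the scatter) and so shows that the group para to a large group on this aromatic ring can alter growth inhibition, which compound 1, without that ring, could not show. Compound 2 has a limit of the assay and not a number, so the full size of this step cannot be read: the limit of > 100000 nM in this assay, at which 1 of the 3 values shown sits. Going by these compounds, whether an amine, a carboxylic acid or a methoxy group at this place would give a lower number than hydroxy stays open. On these data alone, whether the same change would act alike on a different core also stays open.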